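Urea aryl variation on a shared piperidine core

The compounds below may be only part of what the source reports. "The series", "measured", "known", "first", "only" and "open" are said of these compounds alone.

Measured so far:
compound 1 `CC(C(=O)NCc1ccc(C(F)(F)F)cc1N1CCC(Cc2ccccc2)(N(C)C)CC1)c1ccc(NS(C)(=O)=O)c(F)c1` — 8.2 nM
compound 2 `CN(C)C1(Cc2ccccc2)CCN(c2cc(C(F)(F)F)ccc2CNC(=O)Nc2ccc3c(c2)OCC3)CC1` — 31.3 nM
compound 3 `CN(C)C1(Cc2ccccc2)CCN(c2cc(C(F)(F)F)ccc2CNC(=O)Nc2cccc3c(=O)[nH]ccc23)CC1` — "not active" (no number reported)

The readout throughout is an assay on CHO cells for antagonist activity at transient receptor potential cation channel subfamily V member 1 (Homo sapiens), read by scintillation counting, with a stated time of 5 min, in the presence of a further agent that is not named here; a higher number here means that more compound is needed for the effect, a lower number that less compound is needed. Compound 1 gives 8.2 nM, compound 2 gives 31.3 nM, and compound 3 is reported only as "not active" (no number reported), so no single number places it on the scale; it stands apart from the two compounds with numbers.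

Compound 4 `CN(C)C1(Cc2ccccc2)CCN(c2cc(C(F)(F)F)ccc2CNC(=O)Nc2cccc3ccncc23)CC1` differs from compound 3 in one place: a group of 10 heavy atoms (9 carbon, 1 nitrogen; one six-membered aromatic ring of carbon only, one six-membered aromatic ring with 1 hetero atom) in place of a group of 11 heavy atoms (9 carbon, 1 nitrogen, 1 oxygen; one six-membered aromatic ring of carbon only, one six-membered aromatic ring with 1 hetero atom), on an amide-type nitrogen. Compound 3 carries no number in this assay. For the measured compounds named here, no step between measured compounds is available as a guide, and the size of the change from compound 3 to compound 4 cannot be anchored. Compound 2 shows that a fused bicyclic aryl on the urea can give 31.3 nM, so a return toward that region is plausible, but the direction from compound 3 is not knowable beyond the scatter. Compound 4 is expected to give about 300 nM, with a range of 30 nM to 3000 nM, and a real chance that only a limit is reported.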

Compound 4, half-maximal effective concentration: 18.7 nM
For compound 4 the middle estimate is 16-fold (1.21 log units) above the measured one; the whole stated range lies above it.
By their numbers in this assay, from the lowest: compound 1; then compounds 4 and 2 (each within the scatter of the next).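

In this assay the isoquinolin-8-yl group on the amide-type nitrogen gives a measurable value in compound 4, whereas compound 3, with the group it replaces, is reported as "not active" (no number reported), so the size of that step cannot be read. The exchange of the two fused groups on this nitrogen gives a 1.7-fold lower number from compound 2 to compound 4 (0.22 log units; within the scatter), so the series tolerates both the oxygen-containing and the nitrogen-containing group here, and this assay does not separate them. No measurement at hand bears on why compound 3 stands apart from compound 4.

Open, on these data alone, is which feature of the group in compound 3 goes with its "not active" report, the carbonyl or the ring hydrogen-bond donor. Also open, as far as these compounds go, is whether a simple phenyl or naphthalen-1-yl group on the same nitrogen would stay in this range.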